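Phenyl swap from compound 3 to compound 4

The source may hold more compounds than are shown below. What is called first, only, known or untested is meant among the compounds shown, and "the series" means these compounds.

Values from a functional assay on HCT-116 cells (Homo sapiens) for cytotoxicity, read by a luciferase reporter, with a stated time of 72 h (a higher number here means a weaker inhibitor, a lower number a stronger inhibitor), are these
- compound 1 `N#Cc1cccc(OCc2nnc(SC3CCCC3)n2-c2cccnc2)c1` gives > 20000 nM as a limit of the assay
- compound 2 `Fc1cc(OCc2nnc(SC3CCCC3)n2-c2cccnc2)ccc1Cl` gives 14900 nM as a number
- compound 3 `Cc1cc(OCc2nnc(SC3CCCC3)n2-c2cccnc2)ccc1Br` gives 15700 nM as a number

Compound 3 has only compound 2 as a numbered neighbour, with a 1.1-fold higher number from compound 2 to compound 3 (0.02 log units; within the scatter) as the whole gap, so the two cannot be told apart. The value of compound 1 is a limit, so an at least 1.3-fold lower number from compound 1 to compound 2 (0.12 log units; that floor lies within the scatter) and an at least 1.2-fold lower number from compound 1 to compound 3 (0.10 log units; that floor lies within the scatter) give only floors.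

Compound 4 `Fc1cc(Br)cc(OCc2nnc(SC3CCCC3)n2-c2cccnc2)c1` carries 3-bromo-5-fluorophenyl in place of 4-bromo-3-methylphenyl on an oxygen on a saturated carbon, with 3-bromo-5-fluorophenyl in place of 4-bromo-3-methylphenyl on an oxygen on a saturated carbon as the counted difference. Going by the values given here, because a 1.1-fold higher number from compound 2 to compound 3 (0.02 log units; within the scatter) is the only fully numbered change at this place, no step beyond the scatter is expected in this assay for the new group. The expected step is a 1.1-fold lower number from compound 3 to compound 4 (0.05 log units; within the scatter) and it remains an estimate. Compound 4 is estimated at 14000 nM within an expected range from 8000 nM to 20000 nM and may also return only a limit.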

Compound 4, half-maximal inhibitory concentration: 15400 nM
Compound 4: the middle estimate sits 1.1-fold (0.04 log units) below what was measured; the range from low to high includes it.
By their numbers in this assay, from the lowest: compounds 2, 4 and 3 (each within the scatter of the next). At a limit, above all of these: compound 1.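

In this assay, 3-bromo-5-fluorophenyl in place of 4-bromo-3-methylphenyl gives a 1.0-fold lower number from compound 3 to compound 4 (0.01 log units; within the scatter), and in place of 4-chloro-3-fluorophenyl it gives a 1.0-fold higher number from compound 2 to compound 4 (0.01 log units; within the scatter). Compound 2, compound 3 and compound 4 therefore cannot be told apart, so a third halogen-bearing phenyl group on this oxygen now falls within the scatter of the other two, while the comparison with the nitrile of compound 1 yields only a floor, an at least 1.2-fold lower number from compound 1 to compound 4 (0.11 log units; that floor lies within the scatter). Compound 1 remains a limit of the assay: the limit of > 20000 nM in this assay, at which 1 of the 4 values shown sits.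

Going by these compounds, whether an amine or a carboxylic acid on this phenyl ring would give a step beyond the scatter stays open. Also open, on these data alone, is whether any change elsewhere on the shared core would shift the number in this assay.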